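Cyclopropyl in place of butyl on the aromatic carbon

This account rests on a few compounds, and the source may have more. Where it says the series, first, only, none or still open, it means among the compounds named here.

Measured so far in a functional assay on the whole organism for inhibition, with Rattus norvegicus as the target; on this read-out lower numbers stand for an effect already at smaller amounts and higher numbers for an effect only at larger amounts of compound:
- compound 1, `CC1CC/C(=N\Nc2ccc(F)cc2)c2ncc(C(=O)O)c(=O)n21`: compound 1 gives > 1000 umol/kg, a limit of the assay.
- compound 2, `CCc1ccc(N/N=C2\CCC(C)n3c2ncc(C(=O)O)c3=O)cc1`: compound 2 gives > 1000 umol/kg, a limit of the assay.
- compound 3, `CCCCc1ccc(N/N=C2\CCC(C)n3c2ncc(C(=O)O)c3=O)cc1`: compound 3 gives 100 umol/kg.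

For the measured compounds named here, compound 3 holds the only number in this assay; the other two values are limits, as the limit of > 1000 umol/kg in this assay, at which 2 of the 3 values shown sit, records. The steps toward compound 3 are an at least 10-fold lower number from compound 1 to compound 3 (1.00 log units; beyond the scatter) and an at least 10-fold lower number from compound 2 to compound 3 (1.00 log units; beyond the scatter), while a step that the two limits leave unreadable from compound 1 to compound 2 cannot be read. Compound 4, `CC1CC/C(=N\Nc2ccc(C3CC3)cc2)c2ncc(C(=O)O)c(=O)n21`, is not yet measured. Its change from compound 3 is cyclopropyl in place of butyl on an aromatic carbon. Both readable steps show the number falling only once butyl stands on that aromatic carbon; with ethyl or fluoro there, only a limit is seen. Cyclopropyl is counted as one heavy atom fewer than butyl and of a size nearer to ethyl, so the number is expected to rise again toward the limit, and the step is estimated at a 3.0-fold higher number from compound 3 to compound 4 (0.48 log units; beyond the scatter). Compound 4 is therefore expected to give about 300 umol/kg in this assay, within a range of 100 umol/kg to 1000 umol/kg, with a real chance that only a limit is reported.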

Compound 4, dose for 50% inhibition: 100 umol/kg
Beside the measured number, compound 4's estimate is 3.0-fold (0.48 log units) above it, within the range that was stated.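

In this assay, for the compounds shown here, butyl is not the only group at this aromatic carbon, para to a large group, that gives a number rather than a limit: with cyclopropyl, 3 heavy atoms and one three-membered ring in place of 4 heavy atoms and no ring, the step is no change at the digits printed from compound 3 to compound 4 (within the scatter). Against the smaller substituents the picture is an at least 10-fold lower number from compound 2 to compound 4 (1.00 log units; beyond the scatter) and an at least 10-fold lower number from compound 1 to compound 4 (1.00 log units; beyond the scatter), so in this set a readable number does not require a butyl chain. Those two steps are bounded on one side only, as compounds 1 and 2 each give a limit: the limit of > 1000 umol/kg in this assay, at which 2 of the 4 values shown sit.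

Still open, from the compounds shown here alone, is whether the ring or the carbon count matters here, a question that propyl or isopropyl at this carbon would address. Also open, going by these compounds, is whether a hexyl chain or a cyclohexyl ring would move the number beyond the scatter.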